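Isoxazole Cinnamoyl Amides: Vero Cell Tolerance of a Bromophenyl Analogue

The source may report more compounds than this note shows. Statements on the series, on what has been measured and on what is new or still open speak of the compounds shown alone.

Compound 1 `COC(=O)c1cc(-c2cccc(NC(=O)c3ccc(/C=C/C(=O)c4ccc(OC)cc4OC)cc3)c2)on1`: > 50 ug/mL
Compound 2 `COC(=O)c1cc(-c2cccc(NC(=O)c3ccc(/C=C/C(=O)c4ccc(F)cc4F)cc3)c2)on1`: > 40 ug/mL
Compound 3 `COC(=O)c1cc(-c2cccc(NC(=O)c3ccc(/C=C/C(=O)c4ccc(OC)c(OC)c4)cc3)c2)on1`: > 50 ug/mL

In an ADME assay on Vero cells (Chlorocebus sabaeus) for cytotoxicity, read by MTT assay, with a stated time of 72 h (a lower number here means that less compound is tolerated, a higher number that more compound is tolerated), compound 1 gives only a limit, > 50 ug/mL, and not a number. Compound 2 likewise sits at a limit, > 40 ug/mL. Compound 3 also sits at a limit, > 50 ug/mL. Compound 1 therefore stands at the limit of > 50 ug/mL in this assay, at which 2 of the 3 values shown sit, while (the limit of > 40 ug/mL in this assay, at which 1 of the 3 values shown sits). For the measured compounds named here, none of the measured steps can be read: a step that the two limits leave unreadable from compound 1 to compound 2, a step that the two limits leave unreadable from compound 1 to compound 3 and a step that the two limits leave unreadable from compound 2 to compound 3.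

Compound 4 `COC(=O)c1cc(-c2cccc(NC(=O)c3ccc(/C=C/C(=O)c4ccccc4Br)cc3)c2)on1` differs from compound 1 by 2-bromophenyl in place of 2,4-dimethoxyphenyl on a carbonyl carbon. The changes on the carbonyl carbon measured so far all left the values at a limit, so no step beyond the scatter is expected in this assay for compound 4, in either direction. Compound 4 is estimated to give about 60 ug/mL, with a range from 30 ug/mL to 150 ug/mL, and most likely again only a limit. The expected step is a step that the limit leaves unreadable from compound 1 to compound 4.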

Compound 4, half-maximal cytotoxic concentration: > 40 ug/mL
Compound 4: only a limit was reported; the forecaster's own chance of this, stated with the estimate: 75%; the middle value lies beyond the limit too.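

In this assay compound 4 gives only a limit, > 40 ug/mL, so its steps from compound 1, compound 2 and compound 3, which also sit at limits, cannot be read. The compounds shown leave open where the half-maximal cytotoxic concentration of any of the four lies.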